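This account rests on a few compounds, and the source may have more. Where it says the series, first, only, none or still open, it means among the compounds named here.

Measured in a functional assay on SK-OV-3 cells (Homo sapiens) for antiproliferative activity, read by MTT assay, with a stated time of 72 h; on this read-out higher numbers stand for weaker inhibition and lower numbers for stronger inhibition
compound 1 `O=C(CCc1cccc2c1B(O)OC2)Nc1ccccc1` gives 200 nM
compound 2 `O=C(CCc1cccc2c1B(O)OC2)Nc1cccc(-c2ccc(F)cc2)c1` gives 93 nM

Of these two numbers, compound 2 at 93 nM is the lower one. The next structure is compound 3 `COc1cc(OC)cc(-c2cccc(NC(=O)CCc3cccc4c3B(O)OC4)c2)c1` with 3,5-dimethoxyphenyl in place of 4-fluorophenyl on an aromatic carbon, meta to a large group, and the counted difference reads 3,5-dimethoxyphenyl in place of 4-fluorophenyl on an aromatic carbon for this exchange.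

For the measured compounds named here, only one measured step bears on it. That step, a 2.2-fold lower number from compound 1 to compound 2 (0.33 log units; beyond the scatter) for 4-fluorophenyl in place of hydrogen, is modest. Going by the values given here, no measured compound carries a 3,5-dimethoxyphenyl, so the data give no direction for the exchange. The expected move is a 1.1-fold higher number from compound 2 to compound 3 (0.03 log units; within the scatter) in this assay and no step beyond the scatter is expected. For compound 3 the estimate is 100 nM with an expected range from 35 nM to 280 nM in this series.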

Compound 3, half-maximal inhibitory concentration: 44 nM
Compound 3: middle estimate off by 2.3-fold (0.36 log units), on the high side, within the range that was stated.
By their numbers in this assay, from the lowest: compound 3; then compound 2; then compound 1.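

In this assay, this aromatic carbon, meta to a large group, distinguishes between aryl groups: 3,5-dimethoxyphenyl in place of 4-fluorophenyl gives a 2.1-fold lower number from compound 2 to compound 3 (0.33 log units; beyond the scatter), so the step seen earlier is not the same for every aryl group. Measured against hydrogen, 3,5-dimethoxyphenyl gives a 4.5-fold lower number from compound 1 to compound 3 (0.66 log units; beyond the scatter), and both aryl groups shown now lower the number at this place, with no compound here going against that. Nothing available accounts for the difference between the two aryl groups.

Still open, as far as these compounds go, is whether both methoxy groups are needed, or whether an outer phenyl ring with a single methoxy group would read like compound 3. Also open, from the compounds shown here alone, is how an amine or a carboxylic acid on the outer ring would read, and whether the order of the aryl groups holds with a longer chain to the shared core.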